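Alkyl Size on the Aromatic Ring and Minimum Effective Dose

This account rests on a few compounds, and the source may have more. Where it says the series, first, only, none or still open, it means among the compounds named here.

Measured so far:
compound 1, `O=c1c(-c2nn[nH]n2)c[nH]c2ccccc12` — 1.25 mg/kg
compound 2, `CC(C)c1cccc2c(=O)c(-c3nn[nH]n3)c[nH]c12` — 1.25 mg/kg

Both compounds were tested in a functional assay on the whole organism (strain Sprague-Dawley) for inhibition, with Rattus norvegicus as the target; a higher number here means that more compound is needed for the effect, a lower number that less compound is needed. Compound 1 gives 1.25 mg/kg and compound 2 gives 1.25 mg/kg. Within the data shown here, the single measured step, no change at the digits printed from compound 1 to compound 2 (within the scatter), shows that isopropyl in place of hydrogen on an aromatic carbon left the dose where it was, so compound 2 stands level with compound 1.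

Compound 3, `Cc1cccc2c(=O)c(-c3nn[nH]n3)c[nH]c12`, is not yet measured. It differs from compound 2 by methyl in place of isopropyl on an aromatic carbon. Among the measured compounds shown here, the only step that bears on this change is no change at the digits printed from compound 1 to compound 2 (within the scatter), which was flat. Since methyl, with its one heavy atom, lies between the hydrogen of compound 1 and the isopropyl of compound 2, no movement beyond the scatter is expected. Compound 3 is therefore estimated to give 1.25 mg/kg, within 0.6 mg/kg to 2.5 mg/kg. The expected step for compound 3 is no change at the digits printed from compound 2 to compound 3 (within the scatter), no change beyond the scatter.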

Compound 3, minimum effective dose: > 5 mg/kg
Compound 3: no number, only a limit; the forecaster's own chance of this, stated with the estimate: 10%; middle value at least 4.0-fold (0.60 log units) away from the limit.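

This aromatic carbon, ortho to a fused ring, proves not to be indifferent to what it carries, which the flat result for hydrogen and isopropyl did not reveal: in this assay, methyl brings an at least 4.0-fold higher number from compound 2 to compound 3 (0.60 log units; beyond the scatter) and an at least 4.0-fold higher number from compound 1 to compound 3 (0.60 log units; beyond the scatter). Size alone therefore does not order these doses, since methyl, with fewer heavy atoms than isopropyl but more than hydrogen, stands apart from both. Compound 3 gives > 5 mg/kg, which is a limit and not a number: the limit of > 5 mg/kg in this assay, at which 1 of the 3 values shown sits.

The compounds shown leave open how far the dose of compound 3 lies past that limit, and they offer no cause for the gap. They also leave open whether an ethyl group, a longer chain or a methoxy group on this aromatic carbon would side with methyl or with isopropyl.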